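Trimming the carbamoyl group of compound 1

The source may hold more compounds than are shown below. What is called first, only, known or untested is meant among the compounds shown, and "the series" means these compounds.

In a functional assay on the whole organism with Mus musculus as the target, in the rotarod test (on this read-out lower numbers stand for an effect already at smaller amounts and higher numbers for an effect only at larger amounts of compound), compound 1 (`CCN(C)C(=O)/C=C1\CCc2c(F)cc(F)cc21`) gives 73 mg/kg and compound 2 (`C/C(=C\C(=O)NC1CC1)c1cccc(F)c1`) gives 71 mg/kg and these two numbers lie within the scatter of each other. Compound 3 (`NC(=O)/C=C1\CCc2c(F)cc(F)cc21`) keeps the core of compound 1 but carries amino in place of ethyl(methyl)amino on a carbonyl carbon. Among the compounds with values here, no measured pair shows what this change does, so in this assay no step beyond the scatter is expected in either direction (estimated step: a 1.0-fold lower number from compound 1 to compound 3 (0.02 log units; within the scatter)). For compound 3 the expected value is 70 mg/kg with an estimated range from 28 mg/kg to 170 mg/kg on this read-out.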

Compound 3, dose for half-maximal effect: 138 mg/kg
For compound 3 the middle estimate is 2.0-fold (0.29 log units) below the measured one; measured number inside the range.
By their numbers in this assay, from the lowest: compounds 2, 1 and 3 (each within the scatter of the next).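

Within the data shown here, this is the first measured pair at this position. In this assay, cutting ethyl(methyl)carbamoyl back to carbamoyl, on the carbonyl carbon of the shared core, gives a 1.9-fold higher number from compound 1 to compound 3 (0.28 log units; within the scatter), so removing both alkyl groups and adding a hydrogen-bond donor produces no step beyond the scatter. Nothing available explains this result. As far as these compounds go, whether a larger group such as morpholine on the carbonyl carbon, or a carboxylic acid in place of the amide, would stay within the scatter remains open. Compound 2 differs from compound 1 in more than one place, so it cannot settle this.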